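A few compounds are considered here, and "the series" means these few. Any claim that something is new, unique, unknown or untested is made for them only; others in the source may bear on it.

Of the compounds shown here, three have been measured so far in a functional assay on thoracic aorta (Rattus norvegicus, strain Wistar), with a stated time of 15 min (on this read-out lower numbers stand for an effect already at smaller amounts and higher numbers for an effect only at larger amounts of compound), and they all carry a large number. Compound 2 (`CC(NC(=O)N(C)S(=O)(=O)c1ccc(Cl)cc1)c1cc(Br)ccc1OCc1ccccc1`) gives 146000 nM and holds the highest of the three, with compound 3 (`CC(NC(=O)N(C)S(=O)(=O)c1ccccc1)c1cc(Br)ccc1OCc1ccccc1`) at 60300 nM and compound 1 (`CC(C)Oc1ccc(Br)cc1C(C)NC(=O)N(C)S(=O)(=O)c1ccccc1`) at 32100 nM on the same read-out. Compound 4 (`CC(C)Oc1ccc(Br)cc1C(C)NC(=O)N(C)S(=O)(=O)c1ccc(Cl)cc1`) has not yet been measured. It differs from compound 2 in one place, with isopropyl in place of benzyl on an oxygen on an aromatic ring. The same exchange, read the other way, was measured in compounds without chloro and came to a 1.9-fold higher number from compound 1 to compound 3 (0.27 log units; within the scatter) and so gives only a weak hint. The other measured step, a 2.4-fold lower number from compound 2 to compound 3 (0.38 log units; beyond the scatter) for hydrogen in place of chloro on an aromatic carbon, concerns a group that compound 2 and compound 4 both carry, so it does not enter this change. What is expected in this assay is therefore a small fall, a 1.9-fold lower number from compound 2 to compound 4 (0.28 log units; within the scatter) as estimated, not clearly beyond the scatter. For compound 4 the estimated value is 77000 nM (expected range 35000 nM to 170000 nM).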

Compound 4, half-maximal effective concentration: 43200 nM
Compound 4: middle estimate off by 1.8-fold (0.25 log units), on the high side; measured number inside the range.
By their numbers in this assay, from the lowest: compounds 1, 4 and 3 (each within the scatter of the next); then compound 2.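

In this assay, isopropyl in place of benzyl on an oxygen on an aromatic ring now gives a step beyond the scatter, a 3.4-fold lower number from compound 2 to compound 4 (0.53 log units; beyond the scatter), where the compounds without chloro had shown only a step within it, yet the two readings of this exchange still agree: the same change on two cores in this assay, a 1.9-fold higher number (0.27 log units; within the scatter) from compound 1 to compound 3 and a 3.4-fold higher number (0.53 log units; beyond the scatter) from compound 4 to compound 2, 1.8-fold (0.26 log units) apart, within the scatter of two such steps Chloro in place of hydrogen on an aromatic carbon, read with isopropoxy on the oxygen, stays within the scatter, a 1.3-fold higher number from compound 1 to compound 4 (0.13 log units; within the scatter), so the clear difference seen with benzyloxy does not clearly recur, although the two readings do not separate: the same change on two cores in this assay, a 2.4-fold lower number (0.38 log units; beyond the scatter) from compound 2 to compound 3 and a 1.3-fold lower number (0.13 log units; within the scatter) from compound 4 to compound 1, 1.8-fold (0.26 log units) apart, within the scatter of two such steps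

The compounds shown span only benzyloxy and isopropoxy at this place, so it remains open how a methyl, a longer chain or an amine on that oxygen would read. Going by these compounds, all four numbers are large, and whether any such group brings the effect down to much smaller amounts also stays open.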